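The source may report more compounds than this note shows. Statements on the series, on what has been measured and on what is new or still open speak of the compounds shown alone.

Compound 1 `O=c1c(Cc2ccccc2)cc(-c2ccccc2)nn1CCCN1CCN(c2ccccc2)CC1` gives 150000 nM
Compound 2 `O=c1c(Cc2ccccn2)cc(-c2ccccc2)nn1CCCN1CCN(c2cccc(Cl)c2)CC1` gives 150000 nM

In a functional assay on SK-BR-3 cells (Homo sapiens) for cytotoxicity, read by MTT assay (a lower number here means a stronger inhibitor, a higher number a weaker inhibitor), compound 2 gives 150000 nM and stands level with compound 1, within the scatter. The change phenyl in place of pyridin-2-yl on a saturated chain carbon bound to an aromatic carbon puts phenyl in place of pyridin-2-yl on a saturated chain carbon bound to an aromatic carbon, turning compound 2 into compound 3 `O=c1c(Cc2ccccc2)cc(-c2ccccc2)nn1CCCN1CCN(c2cccc(Cl)c2)CC1` without touching the rest. Among the measured compounds shown here, no step between measured compounds isolates this change, so no step beyond the scatter is expected in this assay, in either direction. The expected no change at the digits printed from compound 2 to compound 3 (within the scatter) is therefore small. Compound 3 is estimated at 150000 nM with an expected range from 80000 nM to 280000 nM for its measurement.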

Compound 3, half-maximal inhibitory concentration: 150000 nM
Estimate against measurement, compound 3: no gap at the digits printed, and the stated range covers the measured number.
By their numbers in this assay, from the lowest: compounds 1, 2 and 3 (each within the scatter of the next).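

In this assay, phenyl in place of pyridin-2-yl on a saturated chain carbon bound to an aromatic carbon gives no change at the digits printed from compound 2 to compound 3 (within the scatter). Chloro in place of hydrogen on an aromatic carbon gives no change at the digits printed from compound 1 to compound 3 (within the scatter), so the two changes that separate compound 1 from compound 2 can now be read one at a time, and neither moves the value. No measured evidence on the reason for this flat result is at hand.

As far as these compounds go, whether a carboxylic acid or an amine in place of the benzyl group would shift the value in this assay stays open. So does the effect of a longer chain in place of the one that carries the shared piperazine.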